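This account rests on a few compounds, and the source may have more. Where it says the series, first, only, none or still open, it means among the compounds named here.

Measured so far:
compound 1 `CCc1nnc(O)n2c(C(C)CC)nc(C)c12` — 45000 nM in a functional assay for inhibition, with Homo sapiens as the target; a higher number here means a weaker inhibitor, a lower number a stronger inhibitor
compound 2 `CCc1nnc(S)n2c(C(C)CC)nc(C)c12` — a limit of the assay, > 48000 nM in this assay
compound 3 `COCc1ncc2cnnc(O)n12` — a limit of the assay, > 48000 nM in this assay

For the measured compounds named here, compound 1 thus holds the only number of the three; the other two entries are the limit of > 48000 nM in this assay, at which 2 of the 3 values shown sit. Compound 4, `CCCc1nc(C)c2c(CC)nnc(O)n12`, differs from compound 1 by hydrogen in place of methyl on a saturated chain carbon bound to an aromatic carbon and a saturated chain carbon. Going by the values given here, the single measured step, an at least 1.0-fold higher number from compound 1 to compound 2 (0.02 log units; that floor lies within the scatter), concerns a different group and does not track this change, so no measured step bears directly on it. The expected step in this assay is therefore no change at the digits printed from compound 1 to compound 4 (within the scatter), within the scatter and in no particular direction. Compound 4 is estimated at 45000 nM, between 20000 nM and 100000 nM, with a real chance that only a limit is returned.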

Compound 4, half-maximal inhibitory concentration: 15600 nM
Beside the measured number, compound 4's estimate is 2.9-fold (0.46 log units) above it; measured number below the stated range.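

The change from sec-butyl to propyl gives a 2.9-fold lower number from compound 1 to compound 4 (0.46 log units; beyond the scatter) in this assay, the first step shown at this position. Losing that methyl goes with a stronger inhibitor, so the position responds to the shape of its chain, and this is the only step shown that clears the scatter. Compound 2 and compound 3 remain at a limit of the assay, not a number: the limit of > 48000 nM in this assay, at which 2 of the 4 values shown sit.

As far as these compounds go, whether an ethyl group, a longer chain or an amine at this position would lower the number again stays open. A single step gives no trend.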